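The compounds below may be only part of what the source reports. "The series", "measured", "known", "first", "only" and "open" are said of these compounds alone.

Measured in an assay on HeLa cells for inhibition of Kinesin-like protein KIF15 (Homo sapiens), read by microscopy, with stated times of 2 s and 20 s, tested at 750 nM; a lower number here means less inhibition, a higher number more inhibition at the concentration tested (going by the name of the read-out):
compound 1 `O=C1Nc2ccc(C(=O)c3ccco3)cc2/C1=C/c1cc(F)c(O)c(F)c1` gives 21%
compound 2 `O=C1Nc2ccc(C(=O)c3ccco3)cc2/C1=C/c1cc(Br)c(O)c(Br)c1` gives 65%
compound 3 `O=C1Nc2ccc(C(=O)c3ccco3)cc2/C1=C/c1ccc(O)nc1` gives 26.5%

Compound 2 stands highest of the three numbers in this assay. The nearest of the other two is a number 38.5 percentage points lower from compound 2 to compound 3 (beyond the scatter); the furthest is a number 44 percentage points higher from compound 1 to compound 2 (beyond the scatter). Both steps away from compound 2 are large and beyond the scatter, whereas a number 5.5 percentage points higher from compound 1 to compound 3 (within the scatter) lies within the scatter, so compound 1 and compound 3 sit together at the low end.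

Compound 4 `O=C1Nc2ccc(C(=O)c3ccco3)cc2/C1=C/c1ccncc1` has not yet been measured in this assay. It differs from compound 2 in one place: pyridin-4-yl in place of 3,5-dibromo-4-hydroxyphenyl on a double-bonded chain carbon bound to a double-bonded ring carbon. For the measured compounds named here, the steps that bear on this are the two that leave the 3,5-dibromo-4-hydroxyphenyl of compound 2: a number 38.5 percentage points lower from compound 2 to compound 3 (beyond the scatter), and the reverse of a number 44 percentage points higher from compound 1 to compound 2 (beyond the scatter). In each case the number fell by a large margin once the dibromo-hydroxyphenyl was gone, landing near the level shared by compound 1 and compound 3. Compound 4 keeps none of the bromines and none of the hydroxy group, so a large drop in this assay is expected, estimated as a number 45 percentage points lower from compound 2 to compound 4 (beyond the scatter). The estimate for compound 4 is 20%, with a range from 5% to 40%.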

Compound 4, a percentage reported as inhibition, at one concentration (the size of the read-out at that concentration, not a potency): 0.8%
For compound 4 the middle estimate is 19.2 percentage points above the measured one; the whole stated range lies above it.
By their numbers in this assay, from the lowest: compound 4; then compounds 1 and 3 (each within the scatter of the next); then compound 2.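

In this assay, the pyridin-4-yl group shows that this place, on a double-bonded chain carbon bound to a double-bonded ring carbon, can read well under the level shared by compound 1 and compound 3, with a number 25.7 percentage points lower from compound 3 to compound 4 (beyond the scatter) and a number 20.2 percentage points lower from compound 1 to compound 4 (beyond the scatter). That shared level is therefore not the bottom of the series, and the span opened by a single change here widens to a number 64.2 percentage points lower from compound 2 to compound 4 (beyond the scatter). Compound 4 is also the only one of the four whose group has no hydroxy and no hydrogen-bond donor, and it is the lowest, with no compound shown going against that pairing, although each step to compound 4 also removes halogens or changes the ring nitrogen, so the loss of the hydroxy cannot be read on its own.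

Nothing available here accounts for these differences in the read-out. Still open, from the compounds shown here alone, is how this place responds to a plain 4-hydroxyphenyl, to chlorine in place of the bromines, or to a methoxy group or an amine in place of the hydroxy, which would separate the part played by the halogens from that of the hydroxy.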